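This account rests on a few compounds, and the source may have more. Where it says the series, first, only, none or still open, it means among the compounds named here.

Measured compounds in an ADME assay on HepG2 cells (Homo sapiens) for inhibition, with a stated time of 48 h; on this read-out higher numbers stand for an effect only at larger amounts of compound and lower numbers for an effect already at smaller amounts:
Compound 1 `COc1ccc(Nc2ncc3c(N4CCN(C)CC4)cccc3n2)cc1` gives only a limit, > 40000 nM.
Compound 2 `CN(C)c1nc(Nc2ccc(F)cc2)nc2ccccc12` gives 20100 nM.
Compound 3 `Brc1ccc(Nc2nc(NCc3ccco3)c3ccccc3n2)cc1` gives 19000 nM.

Compound 3 and compound 2 sit within the scatter of each other. Compound 1 is recorded only as a limit (the limit of > 40000 nM in this assay, at which 1 of the 3 values shown sits). Within the data shown here, no two measured compounds differ in a single place, so no measured step exists. Compound 4 `NC(=O)c1ccc(Nc2nc(NCc3ccco3)c3ccccc3n2)cc1` departs from compound 3 by one change: carbamoyl in place of bromo on an aromatic carbon. Among the measured compounds shown here, with no comparable measured step to lean on, the step expected for compound 4 is small, a 1.3-fold higher number from compound 3 to compound 4 (0.12 log units; within the scatter), towards a higher number or none beyond the scatter. Compound 4 is estimated at 25000 nM, with a range from 10000 nM to 60000 nM.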

Compound 4, half-maximal effective concentration: 20000 nM
The estimate for compound 4 lay 1.3-fold (0.10 log units) above the measured number, and the stated range covers the measured number.
By their numbers in this assay, from the lowest: compounds 3, 4 and 2 (each within the scatter of the next). At a limit, above all of these: compound 1.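

In this assay, among these compounds, the only single-place step reads a 1.1-fold higher number from compound 3 to compound 4 (0.02 log units; within the scatter), for carbamoyl in place of bromo on an aromatic carbon. At this position, para to a large group, the read-out therefore shows no shift beyond the scatter, even though the entering carbamoyl brings a hydrogen-bond donor and a hydrogen-bond acceptor that bromo lacks.

As far as these compounds go, whether an amine, a carboxylic acid or a longer chain at this position would move the number stays open. No measured property on hand bears on this result.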